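This account rests on a few compounds, and the source may have more. Where it says the series, first, only, none or still open, it means among the compounds named here.

Measured so far:
compound 1, `Nc1nc(O)c2c(n1)n(C1OC(CO)[C@@H](O)[C@H]1O)c(=O)n2CC(O)CO`: 136%
compound 2, `Nc1nc(O)c2nc(S)n(COCCO)c2n1`: 0%

The read-out is a functional assay on the whole organism (B cells) with Mus musculus as the target; on this read-out higher numbers stand for larger maximal responses and lower numbers for smaller maximal responses. Compound 1 holds the highest number of the two measured compounds; compound 2, the only other one, gives a far lower number, and that gap lies beyond the scatter. Within the data shown here, the two compounds differ in more than one place, so no single step connects them, and their two values are all that can be said of that pair.

Compound 3, `Nc1nc(O)c2c(n1)n(C1OC(CO)[C@@H](O)[C@H]1O)c(=O)n2Cc1ccccc1`, has not been measured. It differs from compound 1 as follows: phenyl in place of 1,2-dihydroxyethyl on a saturated chain carbon bound to an aromatic nitrogen. Among the measured compounds shown here, no measured pair carries this change, so the series itself gives no guide to its size or direction. The expectation is that compound 3 keeps a large maximal response in this assay, with an estimated step of a number 11 percentage points lower from compound 1 to compound 3 (beyond the scatter), no larger than the scatter in either direction. Compound 3 is estimated at 125% in this assay, with an expected range from 75% to 165%.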

Compound 3, largest response reached (reported as maximal response), in percent of the reference or control that the assay uses: 110%
For compound 3 the middle estimate is 15 percentage points above the measured one; measured number inside the range.
By their numbers in this assay, from the lowest: compound 2; then compound 3; then compound 1.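

Among these compounds, the first single-place step shows that this position is sensitive to the group it carries: in this assay phenyl in place of 1,2-dihydroxyethyl on a saturated chain carbon bound to an aromatic nitrogen gives a number 26 percentage points lower from compound 1 to compound 3 (beyond the scatter) and so moves the response by more than repeat measurements would. A large response still survives the change, since compound 3 gives 110% with the hydrogen-bond donors and acceptors of the 1,2-dihydroxyethyl group gone, so the two hydroxyl groups of the 2,3-dihydroxypropyl chain are not required for a large response on the core of compound 1. Nothing at hand explains the size of this step.

This single step cannot separate the loss of the two hydroxyl groups from the arrival of the phenyl ring, and a plain propyl chain in the same place would be needed to tell the two apart. On these data alone, how an amine, a carboxylic acid or a longer chain ending in phenyl would behave at this position also stays open.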